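Aryl variation on the hydrazone carbon: outlook for compound 4

The compounds below may be only part of what the source reports. "The series", "measured", "known", "first", "only" and "open" are said of these compounds alone.

Measured so far:
compound 1 `CN(C)CCn1cnnc1-c1cc(Oc2ccc(NC(=O)N/N=C/c3c[nH]c4ccccc34)cc2F)ccn1` — 1300 nM
compound 2 `COc1ccc(/C=N/NC(=O)Nc2ccc(Oc3ccnc(-c4nncn4CCN(C)C)c3)c(F)c2)c(OC)c1` — 1780 nM
compound 3 `CN(C)CCn1cnnc1-c1cc(Oc2ccc(NC(=O)N/N=C/c3ccccc3O[N+](=O)[O-])cc2F)ccn1` — 950 nM

All three share one core and differ only in the aryl group on the carbon with a double bond to nitrogen. In a functional assay on HT-29 cells (Homo sapiens) for cytotoxicity, read by MTT assay, with a stated time of 72 h (on this read-out higher numbers stand for weaker inhibition and lower numbers for stronger inhibition), compound 3 gives the smallest of the three numbers, yet the step of a 1.4-fold lower number from compound 1 to compound 3 (0.14 log units; within the scatter) and the step of a 1.9-fold lower number from compound 2 to compound 3 (0.27 log units; within the scatter) both fall within the scatter, as does the step of a 1.4-fold higher number from compound 1 to compound 2 (0.14 log units; within the scatter); the three compounds are therefore not separated by these measurements.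

Compound 4 `CN(C)CCn1cnnc1-c1cc(Oc2ccc(NC(=O)N/N=C/c3ccc(F)cc3)cc2F)ccn1` is the next member. The change from compound 3 is 4-fluorophenyl in place of 2-(nitrooxy)phenyl on a carbon with a double bond to nitrogen. Every measured step in the series bears on exactly this place, and none of them moved the number beyond the scatter, whether the group entering was 1H-indol-3-yl, 2,4-dimethoxyphenyl or 2-(nitrooxy)phenyl. Nothing in the data points to 4-fluorophenyl behaving differently, so the expected step is a 1.3-fold higher number from compound 3 to compound 4 (0.10 log units; within the scatter), that is, none beyond the scatter.

On that basis compound 4 is estimated at 1200 nM in this assay, with a range of 500 nM to 2800 nM.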

Compound 4, half-maximal inhibitory concentration: 1370 nM
The estimate for compound 4 lay 1.1-fold (0.06 log units) below the measured number; the measured number falls inside the stated range.
By their numbers in this assay, from the lowest: compounds 3, 1, 4 and 2 (each within the scatter of the next).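

In this assay, 4-fluorophenyl on the carbon with a double bond to nitrogen extends the series to a fourth aryl group, and all its steps lie within the scatter (a 1.4-fold higher number from compound 3 to compound 4 (0.16 log units; within the scatter); a 1.3-fold lower number from compound 2 to compound 4 (0.11 log units; within the scatter); a 1.1-fold higher number from compound 1 to compound 4 (0.02 log units; within the scatter)). The change from 2-(nitrooxy)phenyl to 4-fluorophenyl removes a double bond outside aromatic rings and all 3 hydrogen-bond acceptors of the leaving group, and the entering group has fewer heavy atoms than the leaving group, yet compound 4 is not separated from compound 3. Across the four compounds, this position therefore accepts a fluorine-bearing phenyl ring with 0 hydrogen-bond donors and 0 hydrogen-bond acceptors without a step beyond the scatter, and no available evidence gives a reason for this.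

All four groups shown are aromatic, so it remains open whether a carboxylic acid, an amine or a longer alkyl chain on this carbon would give a step beyond the scatter. Going by these compounds, it also remains open whether the four compounds would stay unseparated on cell lines other than the one used in this assay.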